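The source may hold more compounds than are shown below. What is called first, only, known or untested is meant among the compounds shown, and "the series" means these compounds.

In a functional assay on MCF7 cells (Homo sapiens) for inhibition, read by MTT assay, with a stated time of 72 h (a lower number here means a stronger inhibitor, a higher number a weaker inhibitor), compound 2 (`Nc1ncnc2c1c(-c1cnc3[nH]ccc3c1)nn2CCCCC(=O)NO`) stands only at a limit (> 150000 nM) and has no number. Compound 3 (`Nc1nc2cc(-c3nn(CCC(=O)NO)c4ncnc(N)c34)ccc2o1`) also gives only a limit (> 100000 nM). Compound 1 (`CNC(=O)CCCCCCCn1nc(-c2cnc3[nH]ccc3c2)c2c(N)ncnc21`) alone gives a number (7570 nM). Compound 4 (`Nc1ncnc2c1c(-c1cnc3[nH]ccc3c1)nn2CCCCCCC(=O)NO`) carries 2-(hydroxycarbamoyl)ethyl in place of hydroxycarbamoyl on a saturated chain carbon, four bonds along the chain from an aromatic nitrogen. Within the data shown here, one measured step bears on this place (an at least 19-fold higher number from compound 1 to compound 2 (1.29 log units; beyond the scatter)), and it is large and beyond the scatter, with 3-(methylcarbamoyl)propyl leaving and hydroxycarbamoyl entering. The reverse direction, towards the longer group, is therefore expected to bring a large step to a lower number in this assay (an at least 50-fold lower number from compound 2 to compound 4 (1.69 log units; beyond the scatter)). Compound 4 is estimated at (3000 nM), with an expected range (300 nM to 40000 nM).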

Compound 4, half-maximal inhibitory concentration: 19800 nM
For compound 4 the middle estimate is 6.6-fold (0.82 log units) below the measured one; low and high end bracket the measured number.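

In this assay, the longer hydroxycarbamoyl-ended chain moves the result off the limit and onto a number: an at least 7.5-fold lower number from compound 2 to compound 4 (0.87 log units; beyond the scatter). As far as these compounds go, compound 2 stands only at a limit, so the true size of that step stays open: the limit of > 150000 nM in this assay, at which 1 of the 4 values shown sits. Extending the chain does not bring the hydroxycarbamoyl series level with the methylcarbamoyl-ended chain: a 2.6-fold higher number from compound 1 to compound 4 (0.42 log units; beyond the scatter).

The compounds shown leave open whether a still longer chain ending in hydroxycarbamoyl would lower the number further. They also leave open how a carboxylic acid at the chain end would compare.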